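Aryl Swap on a Spirocyclic Core That Shows No Potency

The compounds below may be only part of what the source reports. "The series", "measured", "known", "first", "only" and "open" are said of these compounds alone.

Of the compounds shown here, two sharing one core have been tested in a functional assay on HepG2 cells (Homo sapiens) for antiproliferative activity, read by MTT assay, with a stated time of 48 h; a higher number here means a weaker inhibitor, a lower number a stronger inhibitor. In this assay compound 1 `Cc1ccc(C)c(-n2nncc2CN2C(=O)C3(C(C#N)=C(N)Oc4c3c3nc5ccccc5nc3c3ccccc43)c3ccccc32)c1` gives > 50000 nM, which is a limit of the assay rather than a measured number. Compound 2 `N#CC1=C(N)Oc2c(N)cc3nc4ccccc4nc3c2C12C(=O)N(Cc1cnnn1-c1ccc(F)cc1)c1ccccc12` likewise gives > 50000 nM in this assay, again a limit and not a number. Both values thus sit at the same place: the limit of > 50000 nM in this assay, at which 2 of the 2 values shown sit. Compound 3 `Cc1ccc(-n2nncc2CN2C(=O)C3(C(C#N)=C(N)Oc4c(N)cc5nc6ccccc6nc5c43)c3ccccc32)cc1Cl` differs from compound 2 in one place, described as 3-chloro-4-methylphenyl in place of 4-fluorophenyl on an aromatic nitrogen. Among the compounds with values here, no step between two measured compounds is available, so the effect of this change on this assay cannot be read from the data, and with compound 2 standing at a limit, only a step of none beyond the scatter can be expected, namely a number no higher from compound 2 to compound 3 (the limit leaves the size open). Compound 3 is therefore expected to give about 50000 nM, within a range from 20000 nM to 200000 nM, most likely again reported only as a limit.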

Compound 3, half-maximal inhibitory concentration: > 50000 nM
Compound 3 was reported as a limit; the forecaster's own chance of this, stated with the estimate: 80%; the middle value sits exactly at the limit.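

No step can be read from compound 2 to compound 3 in this assay, because both are reported only as limits of the assay: the limit of > 50000 nM in this assay, at which 3 of the 3 values shown sit. The compounds shown leave open whether any change on the shared core would give an actual number in this assay.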